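This account rests on a few compounds, and the source may have more. Where it says the series, first, only, none or still open, it means among the compounds named here.

In a functional assay on HEK293 cells (Homo sapiens) for cytotoxicity (on this read-out lower numbers stand for higher toxicity in this test and higher numbers for lower toxicity in this test), compound 3, `COc1ccc([C@H]2CC(=O)N(c3cccc(C)c3)C2)cc1OC1CCCC1`, gives > 10000 nM, which is a limit of the assay rather than a measured number. Compound 1, `COc1ccc([C@H]2CC(=O)N(Cc3cccc(N)c3)C2)cc1OC1CCCC1`, likewise reaches only a limit in this assay, at > 10000 nM. Compound 2, `COc1ccc([C@H]2CC(=O)N(c3ccc(N)cc3)C2)cc1OC1CCCC1`, also stops at a limit in this assay, at > 10000 nM. Because of the limit of > 10000 nM in this assay, at which 3 of the 3 values shown sit, none of the steps among these three can be read: a step that the two limits leave unreadable from compound 1 to compound 2, a step that the two limits leave unreadable from compound 1 to compound 3 and a step that the two limits leave unreadable from compound 2 to compound 3 are all unreadable in size. Compound 4, `COc1ccc([C@H]2CC(=O)N(c3cccc(NS(=O)(=O)c4cc(Br)c(Cl)s4)c3)C2)cc1OC1CCCC1`, carries ((4-bromo-5-chlorothiophen-2-yl)sulfonyl)amino in place of methyl on an aromatic carbon. Going by the values given here, no measured step gives a readable size for this change, so no direction beyond the scatter can be expected from the data. The step that this estimate means, a step that the limit leaves unreadable from compound 3 to compound 4, is expected to lie within the scatter. Compound 4 is expected to give 12000 nM in this assay, within 3000 nM to 50000 nM.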

Compound 4, half-maximal cytotoxic concentration: > 10000 nM
Compound 4: no number, only a limit; the forecaster's own chance of this, stated with the estimate: 70%; the middle value is on the limit's open side.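

Going by these compounds alone, no step from compound 3 to compound 4 can be read, because both values are limits and not numbers: the limit of > 10000 nM in this assay, at which 4 of the 4 values shown sit.

In this assay the compounds shown leave open whether any of these group changes alters toxicity at all.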